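The source may hold more compounds than are shown below. What is called first, only, known or untested is meant among the compounds shown, and "the series" means these compounds.

Measured in a functional assay on MCF7 cells (Homo sapiens) for antiproliferative activity, read by MTT assay, with a stated time of 48 h; a higher number here means a weaker inhibitor, a lower number a stronger inhibitor:
- Compound 1 `O=[N+]([O-])c1cccc(-c2nn(-c3ccccc3)cc2C(Nc2nc3ccccc3s2)c2c(O)ccc3ccccc23)c1`: 43900 nM
- Compound 2 `Oc1ccc2ccccc2c1C(Nc1nc2ccccc2s1)c1cn(-c2ccccc2)nc1-c1cccc(Cl)c1`: 20700 nM
- Compound 3 `Cc1ccc(-c2nn(-c3ccccc3)cc2C(Nc2nc3ccccc3s2)c2c(O)ccc3ccccc23)cc1`: 13100 nM

Of these three, compound 1 stands highest at 43900 nM, which makes it the weakest inhibitor. Compound 4 `Oc1ccc2ccccc2c1C(Nc1nc2ccccc2s1)c1cn(-c2ccccc2)nc1-c1ccc(I)cc1` has not yet been measured. It differs from compound 1 by 4-iodophenyl in place of 3-nitrophenyl on an aromatic carbon, with 4-iodophenyl in place of 3-nitrophenyl on an aromatic carbon. Two measured changes that remove the nitro group bear on this: a 2.1-fold lower number from compound 1 to compound 2 (0.33 log units; beyond the scatter) and a 3.4-fold lower number from compound 1 to compound 3 (0.53 log units; beyond the scatter). Both are modest, and a 1.6-fold lower number from compound 2 to compound 3 (0.20 log units; within the scatter) stays within the scatter. Within the data shown here, no iodo compound has been measured, so a similar modest fall is only an expectation in this assay. The estimated change is a 2.6-fold lower number from compound 1 to compound 4 (0.41 log units; beyond the scatter). Compound 4 is expected at 17000 nM, within an estimated range of 7000 nM to 40000 nM.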

Compound 4, half-maximal inhibitory concentration: 18900 nM
Compound 4: middle estimate off by 1.1-fold (0.05 log units), on the low side; the measured number falls inside the stated range.
By their numbers in this assay, from the lowest: compounds 3, 4 and 2 (each within the scatter of the next); then compound 1.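

Replacing 3-nitrophenyl with 4-iodophenyl gives a 2.3-fold lower number from compound 1 to compound 4 (0.37 log units; beyond the scatter) in this assay, so a third group at this position reads modestly stronger than the nitro compound. Iodo adds no clear separation from the other replacements: a 1.4-fold higher number from compound 3 to compound 4 (0.16 log units; within the scatter) and a 1.1-fold lower number from compound 2 to compound 4 (0.04 log units; within the scatter) both lie within the scatter, so compounds 2, 3 and 4 cannot be told apart. From the compounds shown here alone, whether an amine or a carboxylic acid on this phenyl ring would leave the number in the same range stays open, and so does the effect of moving the iodo group around the ring. No available evidence gives a reason for these steps.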